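A few compounds are considered here, and "the series" means these few. Any claim that something is new, unique, unknown or untested is made for them only; others in the source may bear on it.

Working notes on the series. In an ADME assay on MT4 cells (Homo sapiens) for cytotoxicity, read by MTT assay (on this read-out higher numbers stand for lower toxicity in this test and lower numbers for higher toxicity in this test), compound 1 `O=C1c2ccccc2C(=O)N1CCOC(=S)N(C(=O)c1cccc([N+](=O)[O-])c1)c1ccc(Cl)cc1` gives 18000 nM and compound 2 `Cc1ccc(N(C(=O)c2cccc([N+](=O)[O-])c2)C(=S)OCCN2C(=O)c3ccccc3C2=O)cc1` gives 100000 nM, the higher of the two numbers. Compound 3 `Cc1ccc(N(C(=O)c2cc(F)ccc2F)C(=S)OCCN2C(=O)c3ccccc3C2=O)cc1` keeps the methyl of compound 2 and differs from it in one place: 2,5-difluorophenyl in place of 3-nitrophenyl on a carbonyl carbon. Going by the values given here, no measured step touches this carbonyl substituent. Among the compounds with values here, the only step available is a 5.6-fold higher number from compound 1 to compound 2 (0.74 log units; beyond the scatter), modest in size and made elsewhere in the molecule, so it offers no more than a rough scale. Since compound 2 holds the higher number at 100000 nM, a modest step towards a lower number is expected in this assay, though a change within the scatter remains possible. The estimate amounts to an expected 2.2-fold lower number from compound 2 to compound 3 (0.35 log units; beyond the scatter). Compound 3 is expected at 45000 nM, with an estimated range of 12000 nM to 130000 nM.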

Compound 3, half-maximal cytotoxic concentration: 62000 nM
Beside the measured number, compound 3's estimate is 1.4-fold (0.14 log units) below it; the range from low to high includes it.
By their numbers in this assay, from the lowest: compound 1; then compounds 3 and 2 (each within the scatter of the next).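

In this assay the carbonyl substituent can now be read: 2,5-difluorophenyl in place of 3-nitrophenyl on a carbonyl carbon gives a 1.6-fold lower number from compound 2 to compound 3 (0.21 log units; within the scatter), so this exchange leaves no difference that can be told from the scatter. That contrasts with the methyl in place of chloro change on the aromatic carbon, which gives a 5.6-fold higher number from compound 1 to compound 2 (0.74 log units; beyond the scatter), a step beyond the scatter; in this pair, the 3-nitrophenyl is not required for a number within the scatter of compound 2. No supporting data bear on why this exchange reads as it does.

Going by these compounds, whether this carbonyl position would accept a phenyl ring carrying a carboxylic acid or an amine, or a cyclohexyl group in place of the aromatic ring, stays open. Also open, on these data alone, is whether 2,5-difluorophenyl would read the same with the chloro of compound 1 in place of the methyl.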